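Naphthalenyl Replaced by Chlorophenyl on the Amine-Bound Carbon

The compounds below may be only part of what the source reports. "The series", "measured", "known", "first", "only" and "open" are said of these compounds alone.

Compound 1: `O=S(=O)(NCCCNCc1ccccc1)c1cc(C(F)(F)F)cc(C(F)(F)F)c1` gives 13000 nM
Compound 2: `O=S(=O)(NCCCNCc1cccc2ccccc12)c1cc(C(F)(F)F)cc(C(F)(F)F)c1` gives 2700 nM

Of the compounds shown here, two have been measured in a functional assay on BXPC-3 cells (Homo sapiens) for inhibition, read by MTT assay, with a stated time of 72 h; on this read-out higher numbers stand for weaker inhibition of growth and lower numbers for stronger inhibition of growth. Within the data shown here, compound 2 holds the lower of the two numbers, and compound 1 stands apart from it by the single measured step, a 4.8-fold lower number from compound 1 to compound 2 (0.68 log units; beyond the scatter). Compound 3 `O=S(=O)(NCCCNCc1cccc(Cl)c1)c1cc(C(F)(F)F)cc(C(F)(F)F)c1` has not yet been measured; it differs from compound 2 by 3-chlorophenyl in place of naphthalen-1-yl on a saturated chain carbon bound to an amine nitrogen. Among the measured compounds shown here, this change reverses part of the measured step: the second ring leaves again, and a chlorine enters on the remaining ring, something no measured pair shows. The measured step is therefore a guide mainly to direction: a higher number than that of compound 2 is expected, probably not reaching the number of compound 1. Compound 3 is estimated at 6000 nM, within 2500 nM to 15000 nM. The expected step is a 2.2-fold higher number from compound 2 to compound 3 (0.35 log units; beyond the scatter).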

Compound 3, concentration for 50% growth inhibition: 3800 nM
The estimate for compound 3 lay 1.6-fold (0.20 log units) above the measured number; low and high end bracket the measured number.
By their numbers in this assay, from the lowest: compounds 2 and 3 (each within the scatter of the next); then compound 1.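

In this assay, a single ring bearing chlorine does as well as the two-ring group at this place: a 1.4-fold higher number from compound 2 to compound 3 (0.15 log units; within the scatter), so 3-chlorophenyl and naphthalen-1-yl cannot be told apart here. Placing chloro on the phenyl ring, in place of hydrogen on an aromatic carbon, gives a 3.4-fold lower number from compound 1 to compound 3 (0.53 log units; beyond the scatter), so a second ring is not the only change to the phenyl group that goes with a lower number. No measurement here bears on why these two different groups give numbers within the scatter of each other.

The compounds shown leave open whether chlorine itself matters, or whether fluoro, methoxy or nitrile on the phenyl ring would serve as well. They also leave open what a second chloro on that ring would do.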